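A few compounds are considered here, and "the series" means these few. Any claim that something is new, unique, unknown or untested is made for them only; others in the source may bear on it.

Compound 1, `COc1ccc(Nc2nc(-c3cccc(F)c3)nc3ccc(F)cc23)cc1`, gives 32300 nM in a functional assay on U2OS cells (Homo sapiens) for cytotoxicity, read by MTT assay, with a stated time of 48 h; on this read-out higher numbers stand for weaker inhibition and lower numbers for stronger inhibition. Compound 2, `Fc1cccc(-c2nc(Nc3cccc(Cl)c3)c3cc(F)ccc3n2)c1`, gives > 50000 nM in this assay, a limit rather than a number. Compound 2 therefore stands at the limit of > 50000 nM in this assay, at which 1 of the 2 values shown sits. Compound 3, `Fc1cccc(-c2nc(Nc3ccccc3Cl)c3cc(F)ccc3n2)c1`, differs from compound 2 by 2-chlorophenyl in place of 3-chlorophenyl on a nitrogen on an aromatic ring. Going by the values given here, the one measured step, an at least 1.5-fold higher number from compound 1 to compound 2 (0.18 log units; that floor lies within the scatter), changed a different group and does not bear on this change. Among the compounds with values here, with no step that speaks to it, compound 3 is expected to stay close to where compound 2 sits, giving a number no higher from compound 2 to compound 3 (the limit leaves the size open). Compound 3 is estimated at 50000 nM, within 20000 nM to 120000 nM.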

Compound 3, half-maximal inhibitory concentration: > 50000 nM
Compound 3 was reported as a limit; the forecaster's own chance of this, stated with the estimate: 60%; the middle value lies on the limit itself.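

With 2-chlorophenyl on the nitrogen, compound 3 gives > 50000 nM in this assay, which is a limit and not a number, so the step from the 3-chlorophenyl of compound 2 cannot be read. Against the 4-methoxyphenyl of compound 1, the change gives an at least 1.5-fold higher number from compound 1 to compound 3 (0.18 log units; that floor lies within the scatter). The two chlorophenyl compounds therefore end at one shared limit: the limit of > 50000 nM in this assay, at which 2 of the 3 values shown sit.

On these data alone, how far either lies past that limit stays open, so the two chlorine placements cannot be ranked. As far as these compounds go, whether a 4-chlorophenyl or a 4-aminophenyl group on this nitrogen would give a readable number also remains open.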